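The source may hold more compounds than are shown below. What is called first, only, known or untested is meant among the compounds shown, and "the series" means these compounds.

Working notes on the series. Compound 1 `COc1cc(/C=N/NC(=O)c2ccncc2)cc(OC)c1O` gives 34% in a functional assay on cells (Mus musculus) for cytotoxicity, read by MTT assay, with a stated time of 24 h, tested at 1 uM; a higher number here means a stronger effect of the compound at the concentration tested, a lower number a weaker effect. Compound 2 `COc1cc(/C=N/Nc2nc3ccccc3s2)cc(OC)c1O` gives 39% in this assay, within the scatter of compound 1 and far short of compound 3. Compound 3 `COc1cc(/C=N/N(C)c2nc3ccccc3s2)cc(OC)c1O` gives 107%; the step of a number 68 percentage points higher from compound 2 to compound 3 (beyond the scatter) is the only methylation measured so far. Compound 4 `COc1cc(/C=N/Nc2nc3ccccc3s2)cc(OC)c1OC` has not been measured; it differs from compound 2 by methyl in place of hydrogen on an oxygen on an aromatic ring. Going by the values given here, the measured methylation sits on a nitrogen, not on an oxygen, so it bears only loosely on this change: it shows that a single methyl can move the number far, but for a methyl on the oxygen no direct precedent exists. Only a small rise a number 6 percentage points higher from compound 2 to compound 4 (within the scatter) is therefore expected. Compound 4 is estimated at 45%, range 25% to 75%.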

Compound 4, a percentage reported as activity, at one concentration (the size of the read-out at that concentration, not a potency): 4%
Compound 4: middle estimate off by 41 percentage points, on the high side; the measured number lies below the stated range.
By their numbers in this assay, from the lowest: compound 4; then compounds 1 and 2 (each within the scatter of the next); then compound 3.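

The hydroxy to methoxy change on this oxygen gives a number 35 percentage points lower from compound 2 to compound 4 (beyond the scatter) in this assay, so a methyl here moves the number the opposite way to the methyl on the nitrogen, which gives a number 68 percentage points higher from compound 2 to compound 3 (beyond the scatter). The free hydroxy thus counts for the read-out at this position, which compound 1, compound 2 and compound 3, all carrying it, could not show. Nothing measured on these compounds accounts for the drop. Still open, as far as these compounds go, is whether an ethyl or a longer chain on this oxygen lowers the number as the methyl does. Also open, from the compounds shown here alone, is whether an amine in place of the hydroxy keeps the number of compound 2.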